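Cyclopropyl in place of trifluoroethyl on the oxadiazole carbon

A few compounds are considered here, and "the series" means these few. Any claim that something is new, unique, unknown or untested is made for them only; others in the source may bear on it.

Measured so far:
compound 1 `Cc1cc(-c2noc(C(F)(F)F)n2)cc(C)c1OCCCc1cc(CS(C)(=O)=O)no1`: > 2.5 h
compound 2 `Cc1cc(CCCOc2c(C)cc(-c3noc(CC(F)(F)F)n3)cc2C)on1`: 0.533 h

Among the measured compounds shown here, in an in vitro ADME assay on microsomes from liver (Simiiformes) (a higher number here means that the compound lasts longer, a lower number that the compound disappears faster), compound 2 gives 0.533 h, the only number in hand. Compound 1 gives > 2.5 h, a limit of the assay rather than a number; (the limit of > 2.5 h in this assay, at which 1 of the 2 values shown sits). Compound 2 therefore stands alone as a measured point. Compound 3 `Cc1cc(CCCOc2c(C)cc(-c3noc(C4CC4)n3)cc2C)on1` differs from compound 2 by cyclopropyl in place of 2,2,2-trifluoroethyl on an aromatic carbon. For the measured compounds named here, no step between measured compounds is available, so the expected size of a 1.1-fold higher number from compound 2 to compound 3 (0.05 log units; within the scatter) is taken as no more than the scatter, in either direction. Compound 3 is estimated at 0.6 h, between 0.25 h and 1.6 h.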

Compound 3, half-life: 2.23 h
Beside the measured number, compound 3's estimate is 3.7-fold (0.57 log units) below it; measured number above the stated range.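

In this assay, cyclopropyl in place of 2,2,2-trifluoroethyl on this aromatic carbon gives a 4.2-fold higher number from compound 2 to compound 3 (0.62 log units; beyond the scatter). Among the compounds shown here, this is the first step that can be read, and it shows that a change of this one group is enough to move the read-out beyond the scatter. Further rises in this assay may no longer print as numbers: the limit of > 2.5 h in this assay, at which 1 of the 3 values shown sits.

One pair cannot separate the loss of the fluorine atoms from the gain of the ring. As far as these compounds go, how a plain ethyl or a cyclobutyl on this carbon would read stays open.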